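Thiazolidinone amide series: aryl exchange on the ring nitrogen

This account rests on a few compounds, and the source may have more. Where it says the series, first, only, none or still open, it means among the compounds named here.

Working notes on the shared core of compound 1 `O=C(NCCCCc1ccccc1)c1cccc(C2SCC(=O)N2c2cnccn2)c1`. In a functional assay on HOS-TE85 cells (Homo sapiens) for inhibition, read by CCK-8 assay, with a stated time of 72 h (on this read-out higher numbers stand for weaker inhibition and lower numbers for stronger inhibition), compound 1 returns only a limit, > 1000 nM, and so gives no number to stand on; this is the case named in the limit of > 1000 nM in this assay, at which 1 of the 3 values shown sits. Compound 2 `COc1ccccc1N1C(=O)CSC1c1cc(C(=O)NCCCCc2ccccc2)cc(C2CC2)c1` gives 23.5 nM in this assay. Among the measured compounds shown here, compound 3 `C#Cc1cc(C(=O)NCCCCc2ccccc2)cc(C2SCC(=O)N2c2ccccc2OC)c1` gives 40.8 nM in this assay, and the only measured step, a 1.7-fold higher number from compound 2 to compound 3 (0.24 log units; within the scatter), concerns ethynyl in place of cyclopropyl on an aromatic carbon. Compound 4 `O=C(NCCCCc1ccccc1)c1cccc(C2SCC(=O)N2c2cccc(F)c2)c1` is not yet measured. It differs from compound 1 by 3-fluorophenyl in place of pyrazin-2-yl on an amide-type nitrogen in a ring. For the measured compounds named here, no measured step touches this position, so the change stands without a direct precedent; compound 2 and compound 3 carry a different aryl group at the same nitrogen and also differ elsewhere, so their values only show that an aryl group there is compatible with potent inhibition. For compound 4 the expectation in this assay is therefore a number below the limit but with wide uncertainty, estimated at 400 nM, between 60 nM and 3000 nM. The estimated step of an at least 2.5-fold lower number from compound 1 to compound 4 (0.39 log units; beyond the scatter) is expected toward stronger inhibition, with a real chance that only a limit is again reported.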

Compound 4, half-maximal inhibitory concentration: 32.4 nM
Beside the measured number, compound 4's estimate is 12-fold (1.09 log units) above it, outside the stated range (below it).
By their numbers in this assay, from the lowest: compounds 2, 4 and 3 (each within the scatter of the next). At a limit, above all of these: compound 1.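

In this assay, among the compounds shown here, 3-fluorophenyl in place of pyrazin-2-yl on the amide-type nitrogen in the ring gives an at least 30-fold lower number from compound 1 to compound 4 (1.48 log units; beyond the scatter), the first measured step at this position. With the rest of the core of compound 1 unchanged, this single aryl exchange is enough to give a value clear of the limit. Compound 1 has only a limit, so the step has a lower bound and no exact size: the limit of > 1000 nM in this assay, at which 1 of the 4 values shown sits.

As far as these compounds go, whether a plain phenyl or a pyridinyl group on this nitrogen would behave more like 3-fluorophenyl or like pyrazin-2-yl remains open, so the feature of the exchange that carries the step cannot be named. Also open, from the compounds shown here alone, is how an amine or a carboxylic acid on this aryl group would read in this assay.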